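A Propiolamide in Place of a Cyanomethyl Amide

The source may hold more compounds than are shown below. What is called first, only, known or untested is meant among the compounds shown, and "the series" means these compounds.

Values so far in a physicochemical assay for pharmacokinetics, read by LC-MS, in phosphate buffer, tested at 1 uM; on this read-out lower numbers stand for a shorter-lived compound and higher numbers for a longer-lived compound:
Compound 1 `Cc1cc2c(C(=O)NCC#N)cccc2n1-c1nc2c(c(NCc3ccccc3)n1)CCCC2` gives > 24 h as a limit
Compound 2 `CC#CCNC(=O)c1cccc2c1cc(C)n2-c1nc2c(c(NCc3ccccc3)n1)COCC2` gives > 24 h as a limit

Compound 1 stands at the limit of > 24 h in this assay, at which 2 of the 2 values shown sit, so it has no exact number. Compound 3 `C#CC(=O)Nc1cccc2c1cc(C)n2-c1nc2c(c(NCc3ccccc3)n1)CCCC2` differs from it by (ethynylcarbonyl)amino in place of (cyanomethyl)carbamoyl on an aromatic carbon, with (ethynylcarbonyl)amino in place of (cyanomethyl)carbamoyl on an aromatic carbon. Among the measured compounds shown here, no measured pair of compounds shows the effect of a single change in this assay, so this expectation is tentative. The expected step that the limit leaves unreadable from compound 1 to compound 3 is none beyond the scatter, in either direction. Compound 3 is estimated at 30 h, within a range of 12 h to 72 h.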

Compound 3, half-life: 0.21 h
Estimate against measurement, compound 3: 140-fold (2.15 log units) above; the whole stated range lies above it.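

The earlier compounds shown here both sat at the limit and showed no movement, but this aromatic carbon proves able to change the read-out: in this assay, (ethynylcarbonyl)amino in place of (cyanomethyl)carbamoyl gives an at least 110-fold lower number from compound 1 to compound 3 (2.05 log units; beyond the scatter). The value for compound 1 is a limit, so this step is a bound and its full size stays unknown: the limit of > 24 h in this assay, at which 2 of the 3 values shown sit.

The compounds shown leave open whether the triple bond or the reversed amide link carries the drop, which a propanoylamino group, with a saturated chain, could separate. They also leave open whether the same change behaves alike on the core of compound 2.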